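The compounds below may be only part of what the source reports. "The series", "measured", "known", "first", "only" and "open" are said of these compounds alone.

Of the compounds shown here, two have been measured in an assay on isolated protein for inhibition of Alpha glucosidase (Homo sapiens); on this read-out lower numbers stand for stronger inhibition and higher numbers for weaker inhibition. Compound 1 `Cc1ccc(C(=O)n2nnc3cc(Cl)c(Cl)cc32)cc1C` gives 3820 nM, and compound 2 `COc1ccc(C(=O)n2nnc3ccccc32)cc1` gives 2990 nM. Of these two numbers compound 2 has the smaller one, though its gap to compound 1 lies within the scatter, so the two cannot be told apart. Compound 3 `CCCCOc1ccc(C(=O)n2nnc3ccccc32)cc1` differs from compound 2 by propyl in place of hydrogen on a saturated chain carbon bound to an oxygen on an aromatic ring. Among the compounds with values here, no measured pair shows this change, so its effect is unknown here. Only a small step toward a lower number is expected, a 1.5-fold lower number from compound 2 to compound 3 (0.17 log units; within the scatter). For compound 3 the expected value in this assay is 2000 nM, with a range from 700 nM to 6000 nM.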

Compound 3, half-maximal inhibitory concentration: 5600 nM
Estimate against measurement, compound 3: 2.8-fold (0.45 log units) below; measured number inside the range.
By their numbers in this assay, from the lowest: compounds 2, 1 and 3 (each within the scatter of the next).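

Replacing methoxy with butoxy on the aromatic ring gives, in this assay, a 1.9-fold higher number from compound 2 to compound 3 (0.27 log units; within the scatter), so compound 2 and compound 3 cannot be told apart. This place on the molecule therefore takes a butyl chain in place of a methyl without a change beyond the usual scatter. Nothing available offers an explanation for this step. Still open, going by these compounds, is whether a longer chain than butoxy would shift the number beyond the scatter. The same holds for a chain carrying an amine or a carboxylic acid.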